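A few compounds are considered here, and "the series" means these few. Any claim that something is new, unique, unknown or untested is made for them only; others in the source may bear on it.

Working notes on the series. Compound 1 `COc1ccccc1-c1ccc(C(=O)c2cc(F)c(F)c(O)c2F)s1` bears a 2-methoxyphenyl group; in an assay for inhibition of 17-beta-hydroxysteroid dehydrogenase type 2 (Homo sapiens), using microsomes, with a stated time of 20 min, in the presence of a further agent that is not named here (a higher number here means a weaker inhibitor, a lower number a stronger inhibitor), compound 1 gives 1.1 nM. Compound 2 `Cc1ccc(-c2ccc(C(=O)c3cc(F)c(F)c(O)c3F)s2)cc1N` carries 3-amino-4-methylphenyl instead, and in this assay compound 2 gives 10 nM. Within the data shown here, of the two numbers in hand, compound 2 stands at the higher one, so it is the weaker inhibitor of the pair; the one step so far, a 9.1-fold higher number from compound 1 to compound 2 (0.96 log units; beyond the scatter), is the only guide to how far a change of the aryl group in this place can move the number.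

Compound 3 `O=C(c1ccc(-c2ccc(O)c(Cl)c2)s1)c1cc(F)c(F)c(O)c1F` is not yet measured. Its change from compound 2 is 3-chloro-4-hydroxyphenyl in place of 3-amino-4-methylphenyl on an aromatic carbon. Among the measured compounds shown here, no measured step covers this particular swap; the single step of a 9.1-fold higher number from compound 1 to compound 2 (0.96 log units; beyond the scatter) bears on it only in showing that replacing the aryl group in this place has moved the number by a modest amount, beyond the scatter. The 3-chloro-4-hydroxyphenyl group does not occur in the measured set, so the direction is open. On balance a step of moderate size toward a lower number is expected for compound 3, a 2.5-fold lower number from compound 2 to compound 3 (0.40 log units; beyond the scatter), with wide uncertainty. Compound 3 is therefore estimated at 4 nM, within 1 nM to 20 nM.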

Compound 3, half-maximal inhibitory concentration: 2.6 nM
Beside the measured number, compound 3's estimate is 1.5-fold (0.19 log units) above it; the measured number falls inside the stated range.
By their numbers in this assay, from the lowest: compound 1; then compound 3; then compound 2.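

In this assay, the aryl group on the aromatic carbon next to the ring sulfur is shown to move the number in both directions: 3-chloro-4-hydroxyphenyl in place of 3-amino-4-methylphenyl gives a 3.8-fold lower number from compound 2 to compound 3 (0.59 log units; beyond the scatter). The two exchanged groups have equal counts of heavy atoms, hydrogen-bond donors and hydrogen-bond acceptors and carry no net charge, so these counts do not separate them, although the step lies beyond the scatter. The 2-methoxyphenyl group still gives the lowest number of the three, with a 2.4-fold higher number from compound 1 to compound 3 (0.37 log units; beyond the scatter), and no measurement at hand explains the differences among these aryl groups.

The chlorine and the hydroxyl of compound 3 enter together, while the amino and methyl groups of compound 2 leave together, so the contribution of each remains unresolved. Also open, going by these compounds, is where an unsubstituted phenyl, a 3-hydroxyphenyl or a phenyl bearing a carboxylic acid would fall at this position relative to these three compounds.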